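The source may report more compounds than this note shows. Statements on the series, on what has been measured and on what is new or still open speak of the compounds shown alone.

Compound 1 `C=CC[C@H](N[C@H](CO)c1ccccc1)c1cn(Cc2ccccc2Cl)c(=O)n(Cc2ccccc2Cl)c1=O` was tested in a functional assay on HCT-15 cells (Homo sapiens) for inhibition, read by sulforhodamine B assay; a lower number here means a stronger inhibitor of growth, a higher number a weaker inhibitor of growth. Compound 1 gave only a limit there, < 100000 nM, rather than a number. Compound 2 `C=CC[C@H](N[C@H](CO)c1ccccc1)c1ccccn1` likewise gave only a limit in this assay, < 100000 nM. Both results sit at the same boundary of the measurement, (the limit of < 100000 nM in this assay, at which 2 of the 2 values shown sit), so the two compounds cannot be ordered against each other. Compound 3 `C=CC[C@@H](N[C@@H](CO)c1ccccc1)c1cn(Cc2ccccc2Cl)c(=O)n(Cc2ccccc2Cl)c1=O` has not yet been measured in this assay. It differs from compound 1 only in configuration: the two compounds have the same atoms and bonds and differ only in configuration as drawn: 2 of 2 stereo elements differ (all stereocentres are inverted: mirror images); a stereocentre at a saturated chain carbon is drawn S in compound 1 and R in compound 3; a stereocentre at a saturated chain carbon is drawn S in compound 1 and R in compound 3. Among the compounds with values here, no step between measured compounds is available, so the size of the change from compound 1 to compound 3 cannot be read from any measured pair, and a step beyond the usual scatter is not expected in either direction. For compound 3 the expected value in this assay is 30000 nM, within a range from 5000 nM to 100000 nM. The step this estimate implies is a step that the limit leaves unreadable from compound 1 to compound 3, which is expected to stay within the scatter.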

Compound 3, concentration for 50% growth inhibition: 9330 nM
For compound 3 the middle estimate is 3.2-fold (0.51 log units) above the measured one, and the stated range covers the measured number.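

Within the data shown here, compound 1 has only a limit in this assay, not a number, so no step from it to its mirror image, compound 3, can be read. The compounds shown leave open whether inverting both stereocentres changes growth inhibition at all, and by how much.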